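A few compounds are considered here, and "the series" means these few. Any claim that something is new, unique, unknown or untested is made for them only; others in the source may bear on it.

Compound 2 `CC(Oc1ccccc1-c1ccc(O)cc1)C1=NCCN1` is a compound tested in a functional assay on CHO cells for agonist activity at Alpha-2C adrenergic receptor (Homo sapiens); a lower number here means a smaller maximal response, a higher number a larger maximal response. In this assay compound 2 gives < 0.3, which is a limit of the assay rather than a number. Compound 1 `CC(Oc1ccccc1-c1ccccc1O)C1=NCCN1` likewise gives only a limit, < 0.3. The step that the two limits leave unreadable from compound 1 to compound 2 cannot be sized, because of the limit of < 0.3 in this assay, at which 2 of the 2 values shown sit. Compound 3 `CC(Oc1ccccc1-c1cccnc1)C1=NCCN1` differs from compound 2 by pyridin-3-yl in place of 4-hydroxyphenyl on an aromatic carbon. The measured steps offer no readable size. A step that the limit leaves unreadable from compound 2 to compound 3 is therefore expected, none beyond the scatter. Compound 3 is estimated at 0.2, with a range from 0.05 to 0.45.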

Compound 3, intrinsic activity: the largest response reached, as a fraction of the reference agonist's: 1
Beside the measured number, compound 3's estimate is 0.80 below it; measured number outside the range, above it.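

At this aromatic carbon, ortho to a group of 8 heavy atoms, the choice of ring can clearly change the maximal response in this assay. Pyridin-3-yl in place of 4-hydroxyphenyl gives a number at least 0.70 higher from compound 2 to compound 3 (beyond the scatter), and in place of 2-hydroxyphenyl it gives a number at least 0.70 higher from compound 1 to compound 3 (beyond the scatter). The two hydroxyphenyl compounds could not show this, and the step between them remains unreadable: the limit of < 0.3 in this assay, at which 2 of the 3 values shown sit.

From the compounds shown here alone, it remains open whether the rise goes with the ring nitrogen of pyridin-3-yl or with the loss of the hydroxyl group, which a plain phenyl could help separate. Going by these compounds, how pyridin-4-yl would behave at this carbon is also open.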